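From Acetyl to 2-Oxopropyl on the Shared Core

A few compounds are considered here, and "the series" means these few. Any claim that something is new, unique, unknown or untested is made for them only; others in the source may bear on it.

In an ADME assay on Vero cells (Chlorocebus sabaeus) for cytotoxicity, read by MTT assay, with a stated time of 72 h (a higher number here means that more compound is tolerated, a lower number that less compound is tolerated), compound 1 `COc1c(N2CCN(CC#N)C(C)C2)c(F)cc2c(=O)c(C(=O)O)cn(C3CC3)c12` gives 354 ug/mL and compound 2 `COc1c(N2CCN(CC(C)=O)C(C)C2)c(F)cc2c(=O)c(C(=O)O)cn(C3CC3)c12` gives 500 ug/mL. Within the data shown here, only two numbers are available, and compound 2 stands within the scatter of compound 1, so the two cannot be separated. Compound 3 `COc1c(N2CCN(CCC(C)=O)C(C)C2)c(F)cc2c(=O)c(C(=O)O)cn(C3CC3)c12` keeps the shared core and differs from compound 2 in one group: 2-oxopropyl in place of acetyl on a saturated chain carbon bound to an amine nitrogen in a ring. Among the measured compounds shown here, the one measured step that bears on this change, made at the same place, is a 1.4-fold higher number from compound 1 to compound 2 (0.15 log units; within the scatter), so no shift beyond the scatter is expected in this assay, and no direction can be foreseen. The expected step is a 1.2-fold lower number from compound 2 to compound 3 (0.08 log units; within the scatter). For compound 3 the estimated value is 420 ug/mL, with an expected range from 200 ug/mL to 800 ug/mL.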

Compound 3, half-maximal cytotoxic concentration: 9.84 ug/mL
The estimate for compound 3 lay 43-fold (1.63 log units) above the measured number, and the stated range ends above it.
By their numbers in this assay, from the lowest: compound 3; then compounds 1 and 2 (each within the scatter of the next).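

The place on a saturated chain carbon bound to an amine nitrogen in a ring turns out to be far from indifferent in this assay. Swapping acetyl for 2-oxopropyl, with the carbonyl kept and the chain longer, gives a 51-fold lower number from compound 2 to compound 3 (1.71 log units; beyond the scatter) and so marks compound 3 as much less tolerated, and 2-oxopropyl in place of cyano gives a 36-fold lower number from compound 1 to compound 3 (1.56 log units; beyond the scatter), although cyano and acetyl could not be separated from each other. No evidence at hand bears on why the number falls so far.

The compounds shown cannot tell whether the fall follows the chain length or the carbonyl at its end. From the compounds shown here alone, it also stays open whether an amine or a carboxylic acid on that chain, or a still longer chain, would keep the low number of compound 3 or return to the level of compound 1 and compound 2.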